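This account rests on a few compounds, and the source may have more. Where it says the series, first, only, none or still open, it means among the compounds named here.

Working notes on the series. Compound 1 `OCCCOc1c(Br)cc(Br)cc1Oc1ccc(Br)cc1Br` in a functional assay on U-937 cells (Homo sapiens) for cytotoxicity, read by MTT assay, with a stated time of 24 h (a higher number here means a weaker inhibitor, a lower number a stronger inhibitor), gives 32.3 ug/mL. Compound 2 `BrCCOc1c(Br)cc(Br)cc1Oc1ccc(Br)cc1Br` in this assay gives 32.5 ug/mL; the step of a 1.0-fold higher number from compound 1 to compound 2 (0.00 log units; within the scatter) left the two numbers indistinguishable within the scatter, so compound 2 stands on a par with compound 1. Compound 3 `C#CCOc1c(Br)cc(Br)cc1Oc1ccc(Br)cc1Br` differs from compound 2 by ethynyl in place of bromomethyl on a saturated chain carbon bound to an oxygen on an aromatic ring. Within the data shown here, only the step from compound 1 to compound 2 bears on this position of the chain, and it was flat, so no step beyond the scatter is expected in this assay from compound 2 to compound 3, meaning a 1.0-fold lower number from compound 2 to compound 3 (0.01 log units; within the scatter). Compound 3 is therefore estimated at 32 ug/mL, with a range of 16 ug/mL to 64 ug/mL.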

Compound 3, half-maximal inhibitory concentration: 29.5 ug/mL
Compound 3: the middle estimate sits 1.1-fold (0.04 log units) above what was measured; low and high end bracket the measured number.
By their numbers in this assay, from the lowest: compounds 3, 1 and 2 (each within the scatter of the next).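

In this assay, ethynyl in place of bromomethyl gives a 1.1-fold lower number from compound 2 to compound 3 (0.04 log units; within the scatter), and ethynyl in place of 2-hydroxyethyl gives a 1.1-fold lower number from compound 1 to compound 3 (0.04 log units; within the scatter). The flat result at this position of the chain, so far seen only between a hydroxyl-ended and a bromo-ended chain, now also covers a chain ending in a triple bond, with all of compound 1, compound 2 and compound 3 within the scatter of each other. Nothing at hand accounts for this flatness. As far as these compounds go, whether an amine, a carboxylic acid or a longer chain here would move the number stays open, as does any change on the shared core.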